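Removing One Chloro Group from Compound 3

The compounds below may be only part of what the source reports. "The series", "measured", "known", "first", "only" and "open" are said of these compounds alone.

Measured compounds:
compound 1 `O=C(CSC(=S)N[C@H]1CCOC1=O)Nc1ccccc1Cl`, > 128000 nM, a limit of the assay
compound 2 `O=C(CSC(=S)N[C@H]1CCOC1=O)Nc1ccc(Cl)cc1Cl`, > 128000 nM, a limit of the assay
compound 3 `O=C(CCl)Nc1ccc(C(=O)/C=C/c2ccc(Cl)cc2)cc1`, 8340 nM

In a functional assay on EC9706 cells (Homo sapiens) for cytotoxicity, read by MTT assay, with a stated time of 72 h (a higher number here means a weaker inhibitor, a lower number a stronger inhibitor), compound 1 gives > 128000 nM, which is a limit rather than a number. Compound 2 gives > 128000 nM, likewise a limit. The step that the two limits leave unreadable from compound 2 to compound 1 is hydrogen in place of chloro on an aromatic carbon, and the two limits the limit of > 128000 nM in this assay, at which 2 of the 3 values shown sit, make its size unreadable. For the measured compounds named here, compound 3 gives 8340 nM in this assay, the only number among the three. The difference between the cores of compound 3 and compound 2 is not broken down here.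

Compound 4 `O=C(CCl)Nc1ccc(C(=O)/C=C/c2ccccc2)cc1` has not been measured. It differs from compound 3 by hydrogen in place of chloro on an aromatic carbon. This is the same kind of change as that from compound 2 to compound 1, but not the same: in compound 2 the place is also meta to a chloro group, whereas in compound 3 it is only para to a large group. As the measured step gives no readable size, the expectation rests on compound 3 at 8340 nM, and a modest step of a 1.6-fold higher number from compound 3 to compound 4 (0.19 log units; within the scatter) is expected. Compound 4 is therefore estimated at 13000 nM in this assay, with a range from 4000 nM to 45000 nM.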

Compound 4, half-maximal inhibitory concentration: 6370 nM
Compound 4: middle estimate off by 2.0-fold (0.31 log units), on the high side; measured number inside the range.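

In this assay, hydrogen in place of chloro, here the change from 4-chlorophenyl to phenyl, gives a 1.3-fold lower number from compound 3 to compound 4 (0.12 log units; within the scatter), so on this core the chloro group can be lost without a difference that stands out from the scatter. This is a single pair on a single core, and it shows nothing about the same change at another place on the ring. For the compounds shown here, the only other pair with this change, on the core of compound 2, cannot be read, so whether the result carries from one core to the other remains untested: the limit of > 128000 nM in this assay, at which 2 of the 4 values shown sit.

The compounds shown leave open whether a different group in the place of the chloro group, such as a methoxy group or an amine, would give a number that differs from compound 3 and compound 4 by more than the scatter. They also leave open which of the several differences between the core of compound 2 and the core of compound 3 matters in this assay.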